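The compounds below may be only part of what the source reports. "The series", "measured", "known", "first", "only" and "open" are said of these compounds alone.

Working notes on the amide series built on the shared core of compound 1 `CCNC(=O)CCc1cccc2c1B(O)OC2`.

In a functional assay on HCT-116 cells (Homo sapiens) for antiproliferative activity, read by MTT assay, with a stated time of 72 h (on this read-out lower numbers stand for stronger inhibition and higher numbers for weaker inhibition), compound 1 gives only a limit, > 100000 nM. Compound 2 `O=C(CCc1cccc2c1B(O)OC2)Nc1nccs1` likewise gives only a limit, > 100000 nM. Compound 3 `O=C(CCc1cccc2c1B(O)OC2)Nc1ccc(F)cc1` gives 650 nM. Compound 1 therefore stands at the weaker end of what the measurements show, because of the limit of > 100000 nM in this assay, at which 2 of the 3 values shown sit.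

The step that the two limits leave unreadable from compound 1 to compound 2 cannot be read, as both values are limits. The step of an at least 150-fold lower number from compound 1 to compound 3 (2.18 log units; beyond the scatter) and the step of an at least 150-fold lower number from compound 2 to compound 3 (2.18 log units; beyond the scatter) are both large.

Compound 4 `Cc1ccc(NC(=O)CCc2cccc3c2B(O)OC3)cc1` is not yet measured in this assay. It differs from compound 1 as follows (4-methylphenyl in place of ethyl on an amide-type nitrogen). For the measured compounds named here, the closest measured step is the one from compound 1 to compound 3, where a six-membered aromatic ring also replaced ethyl on the amide-type nitrogen and brought a large downward step. A step of similar kind and direction is therefore expected here, with a value for compound 4 estimated at 900 nM, within 200 nM to 5000 nM. The step this implies for compound 4 is expected to be an at least 110-fold lower number from compound 1 to compound 4 (2.04 log units; beyond the scatter).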

Compound 4, half-maximal inhibitory concentration: 4500 nM
Compound 4: the middle estimate sits 5.0-fold (0.70 log units) below what was measured; the measured number falls inside the stated range.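

In this assay, 4-methylphenyl on the amide-type nitrogen, like 4-fluorophenyl, gives a number clear of the limit values, with an at least 22-fold lower number from compound 1 to compound 4 (1.34 log units; beyond the scatter) and an at least 22-fold lower number from compound 2 to compound 4 (1.34 log units; beyond the scatter). Both steps are bounded on one side only: the limit of > 100000 nM in this assay, at which 2 of the 4 values shown sit.

What is new is that the aromatic ring alone does not set the result, since methyl in place of fluoro on an aromatic carbon gives a 6.9-fold higher number from compound 3 to compound 4 (0.84 log units; beyond the scatter).

The compounds shown leave open how an amine or a nitrile on that aromatic carbon would compare with fluoro and methyl. They also leave open whether an unsubstituted phenyl on the amide-type nitrogen would fall nearer to compound 3 or to compound 4.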